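Adding a second methoxy to the benzyl of compound 3

This account rests on a few compounds, and the source may have more. Where it says the series, first, only, none or still open, it means among the compounds named here.

Of the compounds shown here, three sharing one core have been measured in a functional assay on MIA PaCa-2 cells (Homo sapiens) for antiproliferative activity, read by sulforhodamine B assay, with a stated time of 48 h; on this read-out higher numbers stand for weaker inhibition of growth and lower numbers for stronger inhibition of growth. Compound 1 `COc1ccc(Cn2cc(CNC(=O)c3cn(-c4ccccc4)nc3-c3ccccc3)nn2)cc1OC` gives 8200 nM. Compound 2 `O=C(NCc1cn(Cc2ccc(Cl)cc2)nn1)c1cn(-c2ccccc2)nc1-c1ccc(F)cc1` gives 280 nM. Compound 3 `COc1ccc(Cn2cc(CNC(=O)c3cn(-c4ccccc4)nc3-c3ccc(F)cc3)nn2)cc1` gives 3700 nM, which places it second highest of the three numbers, between the other two. Going by the values given here, the one single-point step among them, a 13-fold higher number from compound 2 to compound 3 (1.12 log units; beyond the scatter), shows methoxy in place of chloro on an aromatic carbon raising the number strongly.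

Compound 4 `COc1ccc(Cn2cc(CNC(=O)c3cn(-c4ccccc4)nc3-c3ccc(F)cc3)nn2)cc1OC` is not yet measured. It differs from compound 3 by methoxy in place of hydrogen on an aromatic carbon. Among the compounds with values here, no measured step isolates this change. The nearest comparison is compound 1, which carries the same 3,4-dimethoxybenzyl but lacks the fluoro: compound 1 gives 8200 nM, and compound 3 gives 3700 nM, so the number for compound 1 is the higher of the two. On that basis a modest rise beyond the scatter is expected for compound 4 in this assay, of about a 1.6-fold higher number from compound 3 to compound 4 (0.21 log units; within the scatter). Compound 4 is therefore estimated at 6000 nM, within a range from 2500 nM to 15000 nM.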

Compound 4, concentration for 50% growth inhibition: > 100000 nM
Compound 4 was reported as a limit (the forecaster's own chance of this, stated with the estimate: 5%); middle value at least 16-fold (1.22 log units) from the limit.
By their numbers in this assay, from the lowest: compound 2; then compound 3; then compound 1. At a limit, above all of these: compound 4.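

In this assay compound 4 stands at a limit and not at a number: the limit of > 100000 nM in this assay, at which 1 of the 4 values shown sits.

Going by these compounds alone, a methoxy on this aromatic carbon, ortho to a methoxy group, thus gives an at least 27-fold higher number from compound 3 to compound 4 (1.43 log units; beyond the scatter), a loss that the earlier compounds did not foretell, and set against the 4-chlorophenyl the 3,4-dimethoxyphenyl gives an at least 350-fold higher number from compound 2 to compound 4 (2.55 log units; beyond the scatter). The 3,4-dimethoxybenzyl alone does not carry the whole loss, as the fluoro on the other aromatic ring gives an at least 12-fold higher number from compound 1 to compound 4 (1.08 log units; beyond the scatter).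

No compound shown pairs the 4-methoxybenzyl with hydrogen in place of that fluoro, so it stays open whether the second methoxy acts the same way without the fluoro. Also open, as far as these compounds go, is whether a hydroxy, an ethoxy or a chloro on this carbon would behave as the methoxy does.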